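Adding a chloro to compound 2: an expected small step

A few compounds are considered here, and "the series" means these few. Any claim that something is new, unique, unknown or untested is made for them only; others in the source may bear on it.

Of the compounds shown here, two have been measured in a functional assay on NCI-H1975 cells (Homo sapiens) for antiproliferative activity, read by MTT assay, with a stated time of 72 h; a lower number here means a stronger inhibitor, a higher number a weaker inhibitor. Compound 1 `COc1cc(F)c(NC(=O)c2ccnc(Cl)c2)cc1Nc1nccc(-c2cn(C)c3ccccc23)n1` gives 4330 nM. Compound 2 `COc1cc(N(C)C)c(NC(=O)c2ccncc2)cc1Nc1nccc(-c2cn(C)c3ccccc23)n1` gives 1470 nM, the lower of the two numbers; the difference to compound 1 lies beyond the scatter. Compound 3 `COc1cc(N(C)C)c(NC(=O)c2ccnc(Cl)c2)cc1Nc1nccc(-c2cn(C)c3ccccc23)n1` has not yet been measured. It differs from compound 2 by chloro in place of hydrogen on an aromatic carbon. For the measured compounds named here, no measured pair shows this single change on its own, so the step is expected to be small, in either direction or none beyond the scatter. Compound 3 is therefore estimated at 1800 nM, within 700 nM to 4500 nM, a step of a 1.2-fold higher number from compound 2 to compound 3 (0.09 log units; within the scatter).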

Compound 3, half-maximal inhibitory concentration: 9200 nM
Compound 3: the middle estimate sits 5.1-fold (0.71 log units) below what was measured, and the stated range ends below it.
By their numbers in this assay, from the lowest: compound 2; then compound 1; then compound 3.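

In this assay the change from pyridin-4-yl to 2-chloropyridin-4-yl gives a 6.3-fold higher number from compound 2 to compound 3 (0.80 log units; beyond the scatter) and so is not neutral at this carbon next to the ring nitrogen. With the 2-chloropyridin-4-yl amide held constant, dimethylamino in place of fluoro gives a 2.1-fold higher number from compound 1 to compound 3 (0.33 log units; beyond the scatter) at the other place that varies, so dimethylamino does not offset the loss seen with chloro. No measurement shown here explains either step. Open, on these data alone, is whether a methyl, a methoxy or an amine at that same carbon would give a lower number than chloro does.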